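A few compounds are considered here, and "the series" means these few. Any claim that something is new, unique, unknown or untested is made for them only; others in the source may bear on it.

Measured compounds:
compound 1 `COc1cc(-n2ncnc2-c2ccc(F)cc2)cc(OC)c1OC`: > 10000 nM
compound 2 `COc1cc(-c2ncnn2-c2cccc([N+](=O)[O-])c2)cc(OC)c1OC`: > 10000 nM
compound 3 `CCOc1ccccc1-c1ncnn1-c1cc(OC)c(OC)c(OC)c1`: > 10000 nM

All three values come from a functional assay on A549 cells (Homo sapiens) for antiproliferative activity, read by MTT assay, with a stated time of 72 h; a higher number here means a weaker inhibitor, a lower number a stronger inhibitor. For compound 1 the value > 10000 nM is a limit of the assay, not a number. Compound 2 likewise gives only a limit in this assay, > 10000 nM. Compound 3 also gives a limit, > 10000 nM. Compound 1 thus stands at the limit together with every other measured compound, as the limit of > 10000 nM in this assay, at which 3 of the 3 values shown sit, shows; no actual number is known for any of them. Compound 4 `COc1cc(-n2ncnc2-c2ccc(Cl)cc2)cc(OC)c1OC` differs from compound 1 by chloro in place of fluoro on an aromatic carbon. Among the compounds with values here, with no measured step to lean on, no step beyond the scatter is expected, and compound 4 is expected to remain at the limit, with an estimated step that the limit leaves unreadable from compound 1 to compound 4. The estimate for compound 4 is 20000 nM, ranging from 8000 nM to 60000 nM.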

Compound 4, half-maximal inhibitory concentration: > 10000 nM
Compound 4 ended at the assay's limit (the forecaster's own chance of this, stated with the estimate: 85%); the middle value is on the limit's open side.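

Compound 1 and compound 4 each give only a limit in this assay, so no step can be read for chloro in place of fluoro. The compounds shown leave open what actual value any of them has.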